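This account rests on a few compounds, and the source may have more. Where it says the series, first, only, none or still open, it means among the compounds named here.

The three measured compounds share one core and differ only at the carbon that carries the amine. Compound 1 `CCCCCCCOc1ccc(CCC(N)(CO)CO)cc1` gives 0.014 mg/kg in a functional assay on the whole organism (spleen, spleen) with Rattus norvegicus as the target; a lower number here means that less compound is needed, a higher number that more compound is needed for the effect. Compound 2 `CCCCCCCOc1ccc(CCC(N)(CC)CO)cc1` gives 0.044 mg/kg in this assay, and compound 3 `CCCCCCCOc1ccc(CCC(N)(CO)C(C)C)cc1` gives 4.5 mg/kg there. Compound 3 thus stands at the highest number of the three: the step of a 100-fold higher number from compound 2 to compound 3 (2.01 log units; beyond the scatter) and the step of a 320-fold higher number from compound 1 to compound 3 (2.51 log units; beyond the scatter) both lie beyond the scatter, while a 3.1-fold higher number from compound 1 to compound 2 (0.50 log units; beyond the scatter) is modest.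

Compound 4 `CCCCCCCOc1ccc(CCC(N)(CO)CCC)cc1` differs from compound 3 as follows: propyl in place of isopropyl on a saturated chain carbon bound to an amine nitrogen and two saturated chain carbons. Among the compounds with values here, no measured step isolates this exact change, so the expectation rests on what the steps around compound 3 show. The step of a 100-fold higher number from compound 2 to compound 3 (2.01 log units; beyond the scatter) is the closest guide, since it shows a large rise when the chain on that carbon becomes branched; compound 4 keeps the same count of carbons but loses the branching. The writer therefore expects compound 4 to move part of the way back toward compound 2, with a step of a 15-fold lower number from compound 3 to compound 4 (1.18 log units; beyond the scatter), and estimates 0.3 mg/kg for compound 4, within a range from 0.05 mg/kg to 2 mg/kg.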

Compound 4, dose for 50% inhibition: 7.3 mg/kg
For compound 4 the middle estimate is 24-fold (1.39 log units) below the measured one; measured number above the stated range.
By their numbers in this assay, from the lowest: compound 1; then compound 2; then compounds 3 and 4 (each within the scatter of the next).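

In this assay, the step of a 1.6-fold higher number from compound 3 to compound 4 (0.21 log units; within the scatter) shows that propyl and isopropyl on this carbon cannot be told apart, so branching in the chain is not needed for the high numbers seen here. The large steps of a 170-fold higher number from compound 2 to compound 4 (2.22 log units; beyond the scatter) and a 520-fold higher number from compound 1 to compound 4 (2.72 log units; beyond the scatter) show that the unbranched propyl of compound 4 stands as far from compound 2 and compound 1 as the isopropyl of compound 3 does, and that a single added methyl at the end of the ethyl of compound 2 is enough for a large rise. Nothing available explains this result.

The compounds shown leave open what methyl or butyl on this carbon would give. They also leave open whether aminomethyl or a carboxylic acid could stand in place of the hydroxymethyl that compound 2 and compound 4 retain.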